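Aryl variation at the shared core: cytotoxicity notes

The source may report more compounds than this note shows. Statements on the series, on what has been measured and on what is new or still open speak of the compounds shown alone.

In an ADME assay on MT4 cells (Homo sapiens) for cytotoxicity, read by MTT assay, with a stated time of 4 days (on this read-out higher numbers stand for lower toxicity in this test and lower numbers for higher toxicity in this test), the three measured compounds gave the following numbers:
compound 1 `Cc1cc(-c2cccc(C(F)(F)F)c2)cc(C)c1Nc1ccnc(Nc2ccc(C#N)cc2)n1` gives 4030 nM
compound 2 `Cc1cc(-c2cc(F)cc(F)c2)cc(C)c1Nc1ccnc(Nc2ccc(C#N)cc2)n1` gives 3910 nM
compound 3 `Cc1cc(-c2cc(Cl)cc(Cl)c2)cc(C)c1Nc1ccnc(Nc2ccc(C#N)cc2)n1` gives 4290 nM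

Compound 2 has the lowest of the three numbers, but its neighbours sit on top of it: the step of a 1.0-fold lower number from compound 1 to compound 2 (0.01 log units; within the scatter) and the step of a 1.1-fold higher number from compound 2 to compound 3 (0.04 log units; within the scatter) are both within the scatter, as is the step of a 1.1-fold higher number from compound 1 to compound 3 (0.03 log units; within the scatter). No order among the three can be read from these values.

Compound 4 `Cc1cc(-c2ccccc2F)cc(C)c1Nc1ccnc(Nc2ccc(C#N)cc2)n1` has not been measured. It differs from compound 2 in one place: 2-fluorophenyl in place of 3,5-difluorophenyl on an aromatic carbon. The three measured steps all concern exchanges of the aryl group on this same aromatic carbon, and none of them moved the number beyond the scatter. The exchange to 2-fluorophenyl is of the same kind, so no step beyond the scatter is expected in this assay, in either direction; the expected step is a 1.0-fold higher number from compound 2 to compound 4 (0.01 log units; within the scatter). For compound 4 the estimate in this assay is 4000 nM, with a range from 2000 nM to 8000 nM.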

Compound 4, half-maximal cytotoxic concentration: 2120 nM
Compound 4: the middle estimate sits 1.9-fold (0.28 log units) above what was measured; low and high end bracket the measured number.
By their numbers in this assay, from the lowest: compounds 4, 2, 1 and 3 (each within the scatter of the next, the first and the last beyond it).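

In this assay the aryl group on this aromatic carbon can shift the number after all: a 2.0-fold lower number from compound 3 to compound 4 (0.31 log units; beyond the scatter) lies beyond the scatter, if only modestly, whereas a 1.8-fold lower number from compound 2 to compound 4 (0.27 log units; within the scatter) and a 1.9-fold lower number from compound 1 to compound 4 (0.28 log units; within the scatter) remain within it. The position therefore allows more spread than the first three aryl groups showed, yet compound 4 separates from compound 3 alone, and that gap is small. Nothing available on these compounds accounts for this single step.

Plain phenyl and 3-fluorophenyl at this carbon would help show whether the step follows the place of the single fluorine or the exchange of the whole aryl group. On these data alone, whether a non-aryl group here, such as an amine, a carboxylic acid or a longer alkyl chain, would move the number further also stays open.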